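A Second Chloro on the Pendant Phenyl of Compound 2

The source may report more compounds than this note shows. Statements on the series, on what has been measured and on what is new or still open speak of the compounds shown alone.

Compound 1 `CCCCc1nn(-c2ccccc2)c(C(=O)O)c1Cc1ccc(-c2ccccc2-c2nn[nH]n2)cc1` in an assay on isolated protein for inhibition of Dipeptidase 1 (Sus scrofa) (on this read-out lower numbers stand for stronger inhibition and higher numbers for weaker inhibition), gives 590000 nM.
Compound 2 `CCCCc1nn(-c2ccccc2Cl)c(C(=O)O)c1Cc1ccc(-c2ccccc2-c2nn[nH]n2)cc1` in this assay gives 350000 nM.

Among these two measured compounds, compound 2 has the lowest number in this assay, and its nearest neighbour is compound 1, whose number is higher by an amount that stays within the scatter. The step that joins them, a 1.7-fold lower number from compound 1 to compound 2 (0.23 log units; within the scatter), is therefore no more than a hint of a direction.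

Compound 3 `CCCCc1nn(-c2cccc(Cl)c2Cl)c(C(=O)O)c1Cc1ccc(-c2ccccc2-c2nn[nH]n2)cc1` is not yet measured. It differs from compound 2 by chloro in place of hydrogen on an aromatic carbon; cut one bond further out, the change reads 2-chlorophenyl to 2,3-dichlorophenyl. Going by the values given here, the only step that bears on it is the one from compound 1 to compound 2, and that step lay within the scatter. On that basis, the step from compound 2 to compound 3 in this assay is expected to be small, a 1.4-fold lower number from compound 2 to compound 3 (0.15 log units; within the scatter), leaning toward a lower number but not clearly beyond the scatter. Compound 3 is thus estimated at 250000 nM, with a range from 100000 nM to 600000 nM.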

Compound 3, inhibition constant: 310000 nM
Estimate against measurement, compound 3: 1.2-fold (0.09 log units) below, within the range that was stated.
By their numbers in this assay, from the lowest: compounds 3, 2 and 1 (each within the scatter of the next).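

In this assay, chloro in place of hydrogen on an aromatic carbon, ortho to a chloro group and meta to a large group, gives a 1.1-fold lower number from compound 2 to compound 3 (0.05 log units; within the scatter), so this position takes the added chloro with no change that can be told from the scatter. Read as a whole, 2,3-dichlorophenyl in place of phenyl on the aromatic nitrogen gives a 1.9-fold lower number from compound 1 to compound 3 (0.28 log units; within the scatter), so even the two chloro groups together do not carry the read-out beyond the scatter, which a single chloro step could not show. Nothing measured here accounts for this lack of a clear change on the pendant ring.

On these data alone, the three compounds therefore set no order among themselves, and it stays open whether a different group at this position, such as a methoxy, an amine or a hydroxyl, would move the number beyond the scatter. Also open, as far as these compounds go, is whether changes elsewhere on the shared core would do so, for example a longer chain in place of the present one, or an amide in place of the carboxylic acid.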